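This account rests on a few compounds, and the source may have more. Where it says the series, first, only, none or still open, it means among the compounds named here.

Compound 1 `COc1ccc(/C=C/S(=O)(=O)Cc2ccc(OC)cc2)cc1` has been examined in a functional assay on H157 cells (Homo sapiens) for antiproliferative activity, read by trypan blue exclusion; a higher number here means a weaker inhibitor, a lower number a stronger inhibitor. In this assay compound 1 gives > 20000 nM, and that figure is a limit of the assay rather than a measured number. Compound 2 `COc1cc(OC)c(/C=C/S(=O)(=O)Cc2ccc(OC)c(OC)c2OC)c(OC)c1` carries further methoxy groups on both rings of the shared core, and in this assay compound 2 gives 15000 nM. Where compound 1 stands can therefore be said only loosely: it sits at the limit of > 20000 nM in this assay, at which 1 of the 2 values shown sits, and the two values together show no more than that compound 2 returned a number while compound 1 did not.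

Compound 3 `COc1ccc(CS(=O)(=O)/C=C/c2ccc([N+](=O)[O-])cc2)cc1` differs from compound 1 in a single place: nitro in place of methoxy on an aromatic carbon. Among the compounds with values here, no measured pair of compounds isolates such a change, so neither the direction nor the size of the step can be read from the data; the one numerical value available, that of compound 2, leaves a weak inhibitor as the nearest reference. Compound 3 is expected to land at 6000 nM, within a range from 1500 nM to 20000 nM, though a further limit rather than a number remains a real possibility. This expectation would amount to a step of an at least 3.3-fold lower number from compound 1 to compound 3 (0.52 log units; beyond the scatter), toward a measurable value.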

Compound 3, half-maximal inhibitory concentration: 7500 nM
Compound 3: the middle estimate sits 1.3-fold (0.10 log units) below what was measured; the measured number falls inside the stated range.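

Within the data shown here, the replacement of methoxy by nitro, on an aromatic carbon para to a large group, gives the one step that can be read so far: in this assay the change amounts to a step of an at least 2.6-fold lower number from compound 1 to compound 3 (0.42 log units; beyond the scatter). Among these compounds, this shows that a single replacement at this position is enough to bring the shared core from a limit to a measured number, and it fixes the direction of the change, which the earlier compounds could not show. Its full size stays unknown because the value of compound 1 is a limit and not a number: the limit of > 20000 nM in this assay, at which 1 of the 3 values shown sits.

What the compounds shown leave open is whether nitro itself matters at this position or whether the loss of methoxy alone would give the same step, as a comparison with an unsubstituted carbon, an amine, a nitrile or a carboxylic acid in the same place could tell. From the compounds shown here alone, it also remains open whether the same replacement on the other aromatic ring of the shared core would move the number in the same direction.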